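The source may hold more compounds than are shown below. What is called first, only, known or untested is meant among the compounds shown, and "the series" means these compounds.

Measured compounds:
compound 1 `O=C(NCN1CCC(c2cccc[n+]2[O-])CC1)c1ccccc1`, 63%
compound 2 `Cc1cccc(C(=O)NCN2CCC(c3cccc[n+]3[O-])CC2)c1`, 77%
compound 3 `Cc1cc(C)cc(C(=O)NCN2CCC(c3cccc[n+]3[O-])CC2)c1`, 56%

In a functional assay on HEK293 cells for agonist activity at D(4) dopamine receptor (Homo sapiens), read by FLIPR (a higher number here means a larger maximal response, a lower number a smaller maximal response), compound 3 gives the lowest of the three numbers, though not clearly apart from all of them. Its nearest neighbour is compound 1, at 63%, a gap within the scatter, so these two cannot be told apart; compound 2 lies furthest, with a number 21 percentage points lower from compound 2 to compound 3 (beyond the scatter). Compound 4 `O=C(NCN1CCC(c2cccc[n+]2[O-])CC1)c1cc(Cl)cc(Cl)c1` differs from compound 3 by 3,5-dichlorophenyl in place of 3,5-dimethylphenyl on a carbonyl carbon. Within the data shown here, no measured step swaps methyl for chlorine, so none bears on it directly; the steps that alter the same phenyl, a number 7 percentage points lower from compound 1 to compound 3 (within the scatter) and a number 21 percentage points lower from compound 2 to compound 3 (beyond the scatter), were small to modest. A step of similar size, or none beyond the scatter, is therefore expected in this assay, with no clear direction. Compound 4 is estimated at 60%, between 40% and 80%. This is expected to mean a number 4 percentage points higher from compound 3 to compound 4 (within the scatter).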

Compound 4, largest response reached (reported as efficacy), in percent of the reference or control that the assay uses: 64%
The estimate for compound 4 lay 4 percentage points below the measured number; the range from low to high includes it.
By their numbers in this assay, from the lowest: compounds 3, 1 and 4 (each within the scatter of the next); then compound 2.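

In this assay, putting two chlorines in place of the two methyl groups on this phenyl, on a carbonyl carbon, changes little, with a number 8 percentage points higher from compound 3 to compound 4 (within the scatter); the plain phenyl is no different, with a number 1 percentage points higher from compound 1 to compound 4 (within the scatter). The 3-methylphenyl group alone stays apart, with a number 13 percentage points lower from compound 2 to compound 4 (beyond the scatter). Nothing measured here explains these numbers.

As far as these compounds go, whether a single chlorine in place of the single methyl would match the 3-methylphenyl group remains open. So does how a methoxy group, an amine or a carboxylic acid on this phenyl would read.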